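Working notes: from compound 3 to compound 4

The compounds below may be only part of what the source reports. "The series", "measured", "known", "first", "only" and "open" are said of these compounds alone.

Within the data shown here, in a physicochemical assay for lipophilicity, read by HPLC, at pH 7.5 (on this read-out lower numbers stand for lower lipophilicity and higher numbers for higher lipophilicity), compound 3 (`CCOc1ccccc1-c1ccc(-c2nc3cnccc3c(N)c2C#N)cc1`) gives 3, the second highest of the three numbers so far. Compound 1 (`CCOc1ccccc1-c1ccc(-c2nc3cnccc3c(N[C@H](CC)C(=O)N(C)C)c2C#N)cc1`) stands higher at 3.7, and compound 2 (`CCOc1ccccc1-c1ccc(-c2nc3cnccc3c(N[C@H](CC)C(=O)NS(=O)(=O)C3CC3)c2C#N)cc1`) stands lower at 2.3.

Compound 4 (`CCOc1ccccc1-c1ccc(-c2nc3cnccc3c(N[C@H](CC)C(=O)NS(C)(=O)=O)c2C#N)cc1`) has not been measured. The change from compound 3 is a group of 10 heavy atoms (5 carbon, 1 nitrogen, 3 oxygen, 1 sulfur; no ring) in place of a hydrogen atom, on a nitrogen on an aromatic ring: a group with no ring takes the place of a hydrogen atom on a nitrogen on an aromatic ring.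

Among the measured compounds shown here, three measured steps bear on this. The closest is a number 0.70 log units higher from compound 2 to compound 3 (beyond the scatter), a modest step beyond the scatter. Compound 2 carries a similar chain ending in a sulfonyl amino unit, and read in reverse that step gives a lower number on adding the chain. The step of a number 0.70 log units lower from compound 1 to compound 3 (beyond the scatter) is also modest, but compound 1 lies on the opposite side of compound 3, so a chain of this length does not fix the direction alone. The large step of a number 1.40 log units lower from compound 1 to compound 2 (beyond the scatter) shows how much the end of the chain matters.

For the measured compounds named here, the entering group lacks the three-membered ring of compound 2, and no measured pair isolates that difference. A modest step towards lower numbers is therefore expected, somewhat beyond the scatter. The expected step is a number 0.90 log units lower from compound 3 to compound 4 (beyond the scatter). For compound 4 the estimated value is 2.1, with an expected range of 1.6 to 2.5.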

Compound 4, distribution coefficient: 2.2
Compound 4: middle estimate off by 0.10 log units, on the low side, within the range that was stated.
By their numbers in this assay, from the lowest: compounds 4 and 2 (each within the scatter of the next); then compound 3; then compound 1.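

In this assay, among these compounds, the step of a number 0.10 log units lower from compound 2 to compound 4 (within the scatter) is the first direct comparison of methyl with cyclopropyl on a sulfonyl sulfur, and this change does not separate the two compounds. Methanesulfonamido in place of dimethylamino on a carbonyl carbon gives the large step of a number 1.50 log units lower from compound 1 to compound 4 (beyond the scatter) and the chain without a ring gives the modest step of a number 0.80 log units lower from compound 3 to compound 4 (beyond the scatter), so among these compounds the unit on the carbonyl carbon matters far more than the choice of methyl or cyclopropyl on the sulfur. No measurement shown accounts for these steps.

Only methyl and cyclopropyl are shown on the sulfonyl sulfur, so it remains open whether phenyl or a longer chain there would also stay within the scatter of compound 2 and compound 4. A carboxylic acid in place of the sulfonyl amino unit on the carbonyl carbon would test whether the sulfonyl group is needed for a number this far below compound 1 , and the effect of the defined stereocentre also remains open, since the opposite configuration is not among the compounds shown.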